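From Chloro to Cyano on a Shared Core

The compounds below may be only part of what the source reports. "The series", "measured", "known", "first", "only" and "open" are said of these compounds alone.

Of the compounds shown here, two with one shared core have been tested in a functional assay on the whole organism (strain CF-1) with Mus musculus as the target, in the writhing test, with a stated time of 15 min; on this read-out higher numbers stand for an effect only at larger amounts of compound and lower numbers for an effect already at smaller amounts. Compound 1, `O=C(/N=C1\NC2(CCCCO2)CCS1)c1ccc(F)cc1`, carries a fluoro on its aromatic ring and gives 8.8 mg/kg; 28 mg/kg; 49 mg/kg (3 entries), a spread recorded as the several entries of compound 1 in this assay, 8.8 mg/kg; 28 mg/kg; 49 mg/kg (3 entries). Within the data shown here, compound 2, `O=C(/N=C1\NC2(CCCCO2)CCS1)c1ccc(Cl)cc1`, carries a chloro instead and gives 1.1 mg/kg; this is the only number for compound 2, and one further entry yielded no single number. Side by side, compound 2 acts at smaller amounts than any of the entries of compound 1. Compound 3, `N#Cc1ccc(C(=O)/N=C2\NC3(CCCCO3)CCS2)cc1`, has not yet been measured in this assay. It differs from compound 2 by cyano in place of chloro on an aromatic carbon. Without a measured pair showing this change, the expected 2.7-fold higher number from compound 2 to compound 3 (0.44 log units; beyond the scatter) is modest, toward larger amounts, near the edge of the scatter. Compound 3 is therefore estimated at 3 mg/kg, within 0.8 mg/kg to 12 mg/kg.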

Compound 3, dose for half-maximal effect: 60 mg/kg
Compound 3: middle estimate off by 20-fold (1.30 log units), on the low side; the measured number lies above the stated range.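

In this assay, putting cyano in place of chloro at this position, para to a large group, proves to be a large change: a 55-fold higher number from compound 2 to compound 3 (1.74 log units; beyond the scatter). One small swap on the aromatic ring can therefore decide whether an effect appears at small amounts of compound or only at much larger ones, which the comparison of fluoro and chloro alone could not show. The size of this step still calls for some care, as the entries for a single compound can lie far apart: the several entries of compound 1 in this assay, 8.8 mg/kg; 28 mg/kg; 49 mg/kg (3 entries).

On these data alone, whether the low number is particular to chloro, or would also appear with a group such as methyl or methoxy at this position, remains open. The compounds shown also do not reveal why cyano shifts the number so far.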